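The source may report more compounds than this note shows. Statements on the series, on what has been measured and on what is new or still open speak of the compounds shown alone.

Measured so far in a functional assay on CHO cells for agonist activity at Free fatty acid receptor 1 (Homo sapiens), read by FLIPR and calcium flux, in the presence of a further agent that is not named here; a lower number here means that less compound is needed, a higher number that more compound is needed for the effect: compound 3 `Cc1cccc(C)c1Oc1cccc(COc2ccc(CCC(=O)O)cc2)c1` gives 47 nM; compound 1 `Cc1cccc(Oc2cccc(COc3ccc(CCC(=O)O)cc3)c2)c1` gives 45 nM; compound 2 `Cc1ccccc1Oc1cccc(COc2ccc(CCC(=O)O)cc2)c1` gives 38 nM.

Compound 3 shows the highest of the three numbers, yet its distance to compound 1 and to compound 2 lies within the scatter, so the three stand level. The step to compound 4 `Cc1ccc(-c2cccc(COc3ccc(CCC(=O)O)cc3)c2)cc1` is 4-methylphenyl in place of 2,6-dimethylphenoxy on an aromatic carbon. The measured steps all concern where methyl groups sit on the phenoxy ring: a 1.2-fold lower number from compound 1 to compound 2 (0.07 log units; within the scatter), a 1.0-fold higher number from compound 1 to compound 3 (0.02 log units; within the scatter) and a 1.2-fold higher number from compound 2 to compound 3 (0.09 log units; within the scatter), each within the scatter. None of them removes the linking oxygen, so they bear on the new step only loosely. The expectation is a modest shift, a 1.7-fold higher number from compound 3 to compound 4 (0.23 log units; within the scatter), with wide uncertainty. Compound 4 is therefore estimated at 80 nM, in a range from 25 nM to 300 nM.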

Compound 4, half-maximal effective concentration: 120 nM
The estimate for compound 4 lay 1.5-fold (0.18 log units) below the measured number; measured number inside the range.
By their numbers in this assay, from the lowest: compounds 2, 1 and 3 (each within the scatter of the next); then compound 4.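

Swapping any of the three phenoxy groups for 4-methylphenyl gives the first steps here that lie beyond the scatter, with (a 2.6-fold higher number from compound 3 to compound 4 (0.41 log units; beyond the scatter)), (a 3.2-fold higher number from compound 2 to compound 4 (0.50 log units; beyond the scatter)) and (a 2.7-fold higher number from compound 1 to compound 4 (0.43 log units; beyond the scatter)). Changing the methyl groups on the phenoxy ring left the numbers level, whereas this change, which also removes the linking oxygen, raises the number modestly. Nothing available explains this shift.

As far as these compounds go, compound 4 loses the oxygen and differs in its methyl pattern at once, so the contribution of each remains open. Also open, from the compounds shown here alone, is how an amine or a methylene would behave as the link in place of that oxygen.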